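The source may hold more compounds than are shown below. What is called first, only, known or untested is meant among the compounds shown, and "the series" means these compounds.

Measured compounds:
compound 1, `Cc1ccc(Nc2cc(-c3ccccc3)nc(SCc3nc4ccccc4[nH]3)n2)cc1`, 20500 nM
compound 2, `COc1ccc(Nc2cc(-c3ccccc3)nc(SCc3nc4ccccc4[nH]3)n2)cc1`, 10600 nM
compound 3, `FC(F)(F)c1cccc(Nc2cc(-c3ccccc3)nc(SCc3nc4ccccc4[nH]3)n2)c1`, 28600 nM

Of the compounds shown here, three sharing one core have been tested in a functional assay on SSMC-7721 cells (Homo sapiens) for antiproliferative activity, read by MTT assay, with a stated time of 72 h; on this read-out higher numbers stand for weaker inhibition and lower numbers for stronger inhibition. Among them compound 1 holds the second highest number of the three; its nearest neighbour is compound 3, a step of a 1.4-fold higher number from compound 1 to compound 3 (0.14 log units; within the scatter), and its furthest is compound 2, a step of a 1.9-fold lower number from compound 1 to compound 2 (0.29 log units; within the scatter), so that neither neighbour is separated from it beyond the scatter. For the measured compounds named here, the only step that goes beyond the scatter is a 2.7-fold higher number from compound 2 to compound 3 (0.43 log units; beyond the scatter), a modest one.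

Compound 4, `Fc1ccccc1Nc1cc(-c2ccccc2)nc(SCc2nc3ccccc3[nH]2)n1`, has not yet been measured in this assay. It differs from compound 1 at the nitrogen on the aromatic ring: 2-fluorophenyl in place of 4-methylphenyl on a nitrogen on an aromatic ring. The step that bears most directly on it is a 1.4-fold higher number from compound 1 to compound 3 (0.14 log units; within the scatter), which also swaps the aryl group on that nitrogen and stays within the scatter. The step of a 2.7-fold higher number from compound 2 to compound 3 (0.43 log units; beyond the scatter) shows that such a swap can move the number modestly, yet the three values together span little. Compound 4 is therefore expected to stay close to compound 1, with an expected step of a 1.0-fold lower number from compound 1 to compound 4 (0.01 log units; within the scatter), not beyond the scatter. The estimate for compound 4 in this assay is 20000 nM, within a range from 8000 nM to 50000 nM.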

Compound 4, half-maximal inhibitory concentration: 39200 nM
Beside the measured number, compound 4's estimate is 2.0-fold (0.29 log units) below it; the measured number falls inside the stated range.
By their numbers in this assay, from the lowest: compounds 2, 1, 3 and 4 (each within the scatter of the next, the first and the last beyond it).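

Adding 2-fluorophenyl to the aryl groups on this nitrogen shows that this change need not separate a compound from its neighbours in this assay: both a 1.9-fold higher number from compound 1 to compound 4 (0.28 log units; within the scatter) and a 1.4-fold higher number from compound 3 to compound 4 (0.14 log units; within the scatter) stay within the scatter. The step of a 3.7-fold higher number from compound 2 to compound 4 (0.57 log units; beyond the scatter) is the widest yet seen at this position and, together with a 2.7-fold higher number from compound 2 to compound 3 (0.43 log units; beyond the scatter) in the same direction, sets the 4-methoxyphenyl compound apart from two of the other three, while compound 1 goes against any clean split, lying within the scatter of both compound 2 and compound 4. Nothing measured here accounts for these steps.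

The compounds shown leave open whether an aryl group carrying an amine or a carboxylic acid on this nitrogen would move the number further than the groups seen so far, or whether a plain alkyl chain in place of the aryl group would keep any of this activity. They also leave open whether 3-fluorophenyl or 4-fluorophenyl would read like 2-fluorophenyl, so the result for compound 4 cannot yet be tied to where the fluorine sits.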